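Swapping a halogenated phenol on a bis-enone scaffold

The source may hold more compounds than are shown below. What is called first, only, known or untested is meant among the compounds shown, and "the series" means these compounds.

Of the compounds shown here, three have been measured in a functional assay on CNE-2 cells (Homo sapiens) for antiproliferative activity, read by sulforhodamine B assay, with a stated time of 48 h; on this read-out higher numbers stand for weaker inhibition and lower numbers for stronger inhibition. Compound 1, `COc1cccc(/C=C/C(=O)C(=Cc2ccc(O)c(F)c2)C(=O)/C=C/c2cccc(OC)c2OC)c1OC`, gives 260 nM. Compound 2, `COc1cc(C=C(C(=O)/C=C/c2cccc(OC)c2OC)C(=O)/C=C/c2cccc(OC)c2OC)cc(Br)c1O`, gives 220 nM. The change between them is 3-bromo-4-hydroxy-5-methoxyphenyl in place of 3-fluoro-4-hydroxyphenyl on a double-bonded chain carbon bound to a double-bonded chain carbon, and it made a 1.2-fold lower number from compound 1 to compound 2 (0.07 log units; within the scatter). Compound 3, `COc1ccc(/C=C/C(=O)C(=Cc2ccc(O)c(F)c2)C(=O)/C=C/c2ccc(OC)cc2OC)c(OC)c1`, gives 2830 nM, the highest of the three; how its core differs from that of compound 1 is not broken down here. Compound 4, `COc1ccc(/C=C/C(=O)C(=Cc2cc(Br)c(O)c(OC)c2)C(=O)/C=C/c2ccc(OC)cc2OC)c(OC)c1`, is not yet measured. It differs from compound 3 by 3-bromo-4-hydroxy-5-methoxyphenyl in place of 3-fluoro-4-hydroxyphenyl on a double-bonded chain carbon bound to a double-bonded chain carbon, the same change as from compound 1 to compound 2. Because the earlier step was a 1.2-fold lower number from compound 1 to compound 2 (0.07 log units; within the scatter), the step to compound 4 is expected to be small as well, estimated at a 1.2-fold lower number from compound 3 to compound 4 (0.07 log units; within the scatter). Compound 4 is therefore estimated at 2400 nM in this assay, with a likely range from 1000 nM to 6000 nM.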

Compound 4, half-maximal inhibitory concentration: 1780 nM
Compound 4: middle estimate off by 1.3-fold (0.13 log units), on the high side, and the stated range covers the measured number.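

In this assay, putting 3-bromo-4-hydroxy-5-methoxyphenyl in place of 3-fluoro-4-hydroxyphenyl gave a 1.6-fold lower number from compound 3 to compound 4 (0.20 log units; within the scatter), so this change stayed small on the core of compound 3 as well. The two cores agree in how little the change does: the same change on two cores in this assay, a 1.2-fold lower number (0.07 log units; within the scatter) from compound 1 to compound 2 and a 1.6-fold lower number (0.20 log units; within the scatter) from compound 3 to compound 4, 1.3-fold (0.13 log units) apart, within the scatter of two such steps. This shows that the two groups can be exchanged on these two cores with no readable shift in the number, but it shows no gain from the exchange and says nothing about any other core.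

The compounds shown leave open whether an amine or a carboxylic acid in place of the hydroxy group would also be tolerated. They also leave open whether the exchange stays this small on a core with ethoxy groups in place of the methoxy groups.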